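Sulfonyl for sulfanyl on the imidazoline aniline series

The compounds below may be only part of what the source reports. "The series", "measured", "known", "first", "only" and "open" are said of these compounds alone.

Two compounds of the shared core have numbers in an assay for binding affinity to Alpha-1D adrenergic receptor (Homo sapiens), read by radioligand binding; a lower number here means a stronger inhibitor, a higher number a weaker inhibitor. Compound 1 `COc1ccc(S(C)(=O)=O)c(NCC2=NCCN2)c1` gives 7590 nM. Compound 2 `CSc1ccc(C)cc1NCC1=NCCN1` gives 17.4 nM and stands lowest of the two, with compound 1 a far higher number, beyond the scatter. Compound 3 `Cc1ccc(S(C)(=O)=O)c(NCC2=NCCN2)c1` is not yet measured in this assay; it differs from compound 2 in one place: methylsulfonyl in place of methylsulfanyl on an aromatic carbon, ortho to a group of 7 heavy atoms and para to a methyl group. For the measured compounds named here, no measured pair shows this exact step, so its size is unknown. Compound 1 also carries methylsulfonyl and gives 7590 nM, but it also differs from compound 2 in a second place, so only part of its gap can be tied to the sulfonyl. A large rise is nonetheless expected, with the step from compound 2 to compound 3 estimated at an 86-fold higher number from compound 2 to compound 3 (1.94 log units; beyond the scatter). Compound 3 is expected to give about 1500 nM, with a likely range from 250 nM to 9000 nM.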

Compound 3, inhibition constant: 4790 nM
Estimate against measurement, compound 3: 3.2-fold (0.50 log units) below; the range from low to high includes it.
By their numbers in this assay, from the lowest: compound 2; then compounds 3 and 1 (each within the scatter of the next).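

In this assay, the change of methylsulfanyl to methylsulfonyl on an aromatic carbon, ortho to a group of 7 heavy atoms and para to a methyl group, now has a size of its own, with nothing else in the structure altered: a 280-fold higher number from compound 2 to compound 3 (2.44 log units; beyond the scatter) is a large step and shows that this one position is highly sensitive to the change. The second place, which had clouded the reading of compound 1, can now be separated out, as methyl in place of methoxy on an aromatic carbon gives a 1.6-fold lower number from compound 1 to compound 3 (0.20 log units; within the scatter) and so has no readable effect while methylsulfonyl is present. No measurement on these compounds bears on why the sulfonyl step is so large.

Open, from the compounds shown here alone, is whether the intermediate methylsulfinyl group, or a sulfonamide or a longer ethylsulfanyl chain at the same position, would stay near compound 2 or near compound 3. Also open, going by these compounds, is whether methyl and methoxy stay interchangeable when methylsulfanyl holds this position, since the swap has been read only with methylsulfonyl present.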